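A few compounds are considered here, and "the series" means these few. Any claim that something is new, unique, unknown or untested is made for them only; others in the source may bear on it.

Compound 1, `Cc1ccc(-c2cn(-c3cc4ccc(O)c(C)c4oc3=O)nn2)cc1`, gives 23200 nM in a functional assay on MCF7 cells (Homo sapiens) for antiproliferative activity; on this read-out higher numbers stand for weaker inhibition and lower numbers for stronger inhibition.
Compound 2, `CC(=O)Oc1ccc2cc(-n3cc(-c4ccc(C)cc4)nn3)c(=O)oc2c1C`, reaches only the limit > 100000 nM in this assay.
Compound 3, `COc1ccc(-c2cn(C3Cc4ccc(O[C@@H]5OC(C)(C)[C@H](OC)[C@@H](O)[C@H]5O)c(C)c4OC3=O)nn2)cc1`, likewise reaches only the limit > 100000 nM in this assay.

Compound 1 thus stands as the only result reported as a number; the other two results are limits, (the limit of > 100000 nM in this assay, at which 2 of the 3 values shown sit). Among the measured compounds shown here, the single measured step, an at least 4.3-fold higher number from compound 1 to compound 2 (0.63 log units; beyond the scatter), concerns the oxygen on the aromatic ring and does not touch the part altered here. Compound 4, `Cc1c(O)ccc2cc(-n3cc(-c4cc5ccccc5[nH]4)nn3)c(=O)oc12`, differs from compound 1 by 1H-indol-2-yl in place of 4-methylphenyl on an aromatic carbon. For the measured compounds named here, no measured step bears on this exchange, so no shift beyond the scatter is expected in this assay in either direction. Compound 4 is therefore estimated at 20000 nM, with a range from 5000 nM to 100000 nM, which would mean an expected step of a 1.2-fold lower number from compound 1 to compound 4 (0.06 log units; within the scatter).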

Compound 4, half-maximal inhibitory concentration: 38300 nM
Beside the measured number, compound 4's estimate is 1.9-fold (0.28 log units) below it, and the stated range covers the measured number.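

On this aromatic carbon of the five-membered aromatic ring with 3 nitrogen, 1H-indol-2-yl in place of 4-methylphenyl gives a 1.7-fold higher number from compound 1 to compound 4 (0.22 log units; within the scatter) in this assay. A second aromatic ring and a hydrogen-bond donor can therefore enter at this position without a shift beyond the scatter. Nothing shown gives a cause for this result. As far as these compounds go, whether an amine or a carboxylic acid on this carbon would move the number beyond the scatter stays open. So does the effect of a saturated ring such as morpholine there.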